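The source may report more compounds than this note shows. Statements on the series, on what has been measured and on what is new or still open speak of the compounds shown alone.

Measured compounds:
compound 1 `Cc1ccc(C2C(C#N)=C(N)N(c3ccc(S(N)(=O)=O)cc3)C3=C2C(=O)CCC3)cc1`, 30%
compound 2 `N#CC1=C(N)N(c2ccc(S(N)(=O)=O)cc2)C2=C(C(=O)CCC2)C1c1c(O)ccc2ccccc12`, 0%

The two compounds were examined in a functional assay on Ehrlich cells (Mus musculus) for antiproliferative activity, read by trypan blue exclusion, with a stated time of 2 h, tested at 10 ug/mL; a higher number here means a stronger effect of the compound at the concentration tested, a lower number a weaker effect. Compound 1 gives 30% in this assay, and compound 2 gives 0%. For the measured compounds named here, compound 2 thus stands at the lower of the two numbers, with compound 1 as its only neighbour, beyond the scatter above it; the step of a number 30 percentage points lower from compound 1 to compound 2 (beyond the scatter) is the one measured change at the saturated ring carbon.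

Compound 3 `N#CC1=C(N)N(c2ccc(S(N)(=O)=O)cc2)C2=C(C(=O)CCC2)C1c1cccs1` is not yet measured. The change is thiophen-2-yl in place of 2-hydroxynaphthalen-1-yl on a saturated ring carbon. Going by the values given here, it touches the same saturated ring carbon as the one known step, which moved the number down by a modest amount when a larger aryl group entered. With a smaller group entering here, the number is expected to move back upward, by an estimated a number 20 percentage points higher from compound 2 to compound 3 (beyond the scatter). Compound 3 is therefore estimated at 20% in this assay, with a range from 0% to 45%.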

Compound 3, a percentage reported as activity, at one concentration (the size of the read-out at that concentration, not a potency): 70%
Compound 3: middle estimate off by 50 percentage points, on the low side; the measured number lies above the stated range.
By their numbers in this assay, from the lowest: compound 2; then compound 1; then compound 3.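

In this assay, the saturated ring carbon turns out to support far more activity than the first two compounds suggested: thiophen-2-yl in place of 2-hydroxynaphthalen-1-yl gives a number 70 percentage points higher from compound 2 to compound 3 (beyond the scatter), and thiophen-2-yl in place of 4-methylphenyl gives a number 40 percentage points higher from compound 1 to compound 3 (beyond the scatter). The second step shows that the gain is not merely a recovery from the loss seen with 2-hydroxynaphthalen-1-yl, since thiophen-2-yl also stands clearly above 4-methylphenyl at this carbon. No available evidence accounts for these differences.

The compounds shown leave open whether the rise belongs to the sulfur of the ring or to the five-membered ring itself, which furan-2-yl or plain phenyl on the same carbon would help to separate. They also leave open how much the 4-sulfamoylphenyl group contributes, since all three compounds carry it.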